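Ester, amide and ketone variants of a branched dienoate chain

The compounds below may be only part of what the source reports. "The series", "measured", "known", "first", "only" and "open" are said of these compounds alone.

Compound 3 `CC(/C=C/CC(C)CCCC(C)C)=C\C(=O)NCC(C)C` has the lowest number of the three measured compounds in a physicochemical assay for lipophilicity (a higher number here means a more lipophilic compound, a lower number a more polar compound), where compound 3 gives 6.19. Compound 2 `CC(/C=C/CC(C)CCCC(C)C)=C\C(=O)OC(C)C` gives 7.15 and compound 1 `CCCOC(=O)/C=C(C)/C=C/CC(C)CCCC(C)C` gives 7.28. The step of a number 0.13 log units lower from compound 1 to compound 2 (within the scatter) shows that exchanging one alkyl ester for another hardly moves the number, whereas a number 1.09 log units lower from compound 1 to compound 3 (beyond the scatter) and a number 0.96 log units lower from compound 2 to compound 3 (beyond the scatter) show that going from an ester to the isobutyl amide lowers it clearly.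

Compound 4 `CCCC(=O)/C=C(C)/C=C/CC(C)CCCC(C)C` differs from compound 3 in one place: propyl in place of isobutylamino on a carbonyl carbon. The change removes the amide entirely and leaves a ketone with no donor, so the steps of a number 1.09 log units lower from compound 1 to compound 3 (beyond the scatter) and a number 0.96 log units lower from compound 2 to compound 3 (beyond the scatter), which both arise from putting in the amide, bear on it in the reverse direction, while a number 0.13 log units lower from compound 1 to compound 2 (within the scatter) shows that the shape of the alkyl piece matters little. A rise is therefore expected, though a ketone is not an ester, so the full ester figure need not be recovered. The step from compound 3 to compound 4 is estimated at a number 0.81 log units higher from compound 3 to compound 4 (beyond the scatter). Compound 4 is expected to give 7 in this assay, with a range from 6.5 to 7.5.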

Compound 4, partition coefficient: 6.81
Compound 4: the middle estimate sits 0.19 log units above what was measured; measured number inside the range.
By their numbers in this assay, from the lowest: compound 3; then compound 4; then compounds 2 and 1 (each within the scatter of the next).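

In this assay, propyl in place of isobutylamino on the carbonyl carbon gives a number 0.62 log units higher from compound 3 to compound 4 (beyond the scatter), so removing the amide at this position moves the number back up. The ketone does not rejoin the esters, however: a number 0.34 log units lower from compound 2 to compound 4 (beyond the scatter) and a number 0.47 log units lower from compound 1 to compound 4 (beyond the scatter) leave it on its own between the amide and the two esters, so the ester, ketone and amide forms are now separated beyond the scatter, whereas the two alkyl esters alone showed only that the ester's alkyl piece changes little. Nothing measured on these compounds accounts for where the ketone falls.

The change from compound 3 to compound 4 alters the atom attached to the carbonyl carbon and the shape of the alkyl piece together, so an isobutyl ketone or a propylamino amide would be needed to tell these two changes apart. On these data alone, a carboxylic acid at the same carbonyl carbon, or a longer chain on the ketone, also remains open, as does whether this order holds on any other core.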